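This account rests on a few compounds, and the source may have more. Where it says the series, first, only, none or still open, it means among the compounds named here.

In a functional assay on MCF7 cells (Homo sapiens) for antiproliferative activity, read by MTT assay, with a stated time of 48 h (on this read-out higher numbers stand for weaker inhibition and lower numbers for stronger inhibition), compound 1 (`CCn1c(C(=O)NCCCN(C)C)ccc1C(CC)(CC)c1ccc(OCCC(O)(CC)CC)c(C)c1`) gives 3350 nM and compound 2 (`CCn1c(C(=O)NCCN(C)C)ccc1C(CC)(CC)c1ccc(OCCC(O)(CC)CC)c(C)c1`) gives 430 nM, a difference described by a 7.8-fold lower number from compound 1 to compound 2 (0.89 log units; beyond the scatter). Compound 3 (`CCOc1ccc(NC(=O)c2ccc(C(CC)(CC)c3ccc(OCCC(O)(CC)CC)c(C)c3)n2CC)cc1`) gives > 50000 nM, which is a limit of this assay and not a number, and it stands at the limit of > 50000 nM in this assay, at which 1 of the 3 values shown sits.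

Compound 4 (`CCn1c(C(=O)NC(CC(=O)O)C(=O)OC)ccc1C(CC)(CC)c1ccc(OCCC(O)(CC)CC)c(C)c1`) changes the group on the amide-type nitrogen of compound 3: a group of 9 heavy atoms (5 carbon, 4 oxygen; no ring) in place of a group of 9 heavy atoms (8 carbon, 1 oxygen; one six-membered aromatic ring of carbon only), on an amide-type nitrogen. Going by the values given here, two measured steps bear on this place, both large: an at least 14-fold higher number from compound 1 to compound 3 (1.17 log units; beyond the scatter) and an at least 110-fold higher number from compound 2 to compound 3 (2.06 log units; beyond the scatter). In each, 4-ethoxyphenyl replaces a chain ending in dimethylamino. The group entering compound 4 has no dimethylamino either, so the numbers of compound 1 and compound 2 are not expected to be regained. Neither step replaces 4-ethoxyphenyl with a group like this one, so they guide the expectation only loosely.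

The expected change is small, and it would run towards a lower number, with an estimated at least 1.2-fold lower number from compound 3 to compound 4 (0.09 log units; that floor lies within the scatter). For compound 4 the estimate is 40000 nM, with an expected range from 8000 nM to 100000 nM.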

Compound 4, half-maximal inhibitory concentration: 10200 nM
Compound 4: the middle estimate sits 3.9-fold (0.59 log units) above what was measured; measured number inside the range.
By their numbers in this assay, from the lowest: compound 2; then compound 1; then compound 4. At a limit, above all of these: compound 3.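

Compound 3 is still the only compound shown without a number, and its value is a limit, not a measurement: the limit of > 50000 nM in this assay, at which 1 of the 4 values shown sits.

Going by these compounds alone, until now, the only measured numbers at this amide-type nitrogen came from chains ending in dimethylamino, but compound 4 shows that a group without that ending can also give one, with an at least 4.9-fold lower number from compound 3 to compound 4 (0.69 log units; beyond the scatter). That group still falls short of both dimethylamino chains, with a 3.0-fold higher number from compound 1 to compound 4 (0.48 log units; beyond the scatter) and a 24-fold higher number from compound 2 to compound 4 (1.38 log units; beyond the scatter), and the gap is clearly wider for the shorter chain of compound 2.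

Compound 4 loses the aromatic ring and gains both a carboxylic acid and a methyl ester, so the compounds shown cannot say which of these differences matters. It also stays open where a plain butyl chain, with no nitrogen or oxygen, or a primary amine at the end of a chain would fall among these values.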